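This account rests on a few compounds, and the source may have more. Where it says the series, first, only, none or still open, it means among the compounds named here.

Compound 1 `Cc1ccc2c(c1C)C(=O)N(Cc1cc(Br)ccc1NC(=O)c1ccccn1)C2=O` and compound 3 `Cc1ccc2c(c1C)C(=O)N(Cc1cc(Cl)ccc1NC(=O)c1ccccn1)C2=O` share one core and differ in a single halogen. In an assay on CHO cells for positive allosteric modulation of metabotropic glutamate receptor 5 (Homo sapiens), read by FLIPR (on this read-out higher numbers stand for an effect only at larger amounts of compound and lower numbers for an effect already at smaller amounts), compound 1 gives only a limit, > 100000 nM. Compound 3 gives 2200 nM in this assay. The change chloro in place of bromo on an aromatic carbon therefore made a large step, an at least 45-fold lower number from compound 1 to compound 3 (1.65 log units; beyond the scatter). Compound 2 `COc1ccc2c(c1OC)C(=O)N(Cc1cc(Br)ccc1NC(=O)c1ccccn1)C2=O` carries another core; the difference between the two cores is not broken down here. In this assay compound 2 likewise gives only a limit, > 100000 nM. Two of the three known values sit at the limit of > 100000 nM in this assay, at which 2 of the 3 values shown sit. Compound 4 `COc1ccc2c(c1OC)C(=O)N(Cc1cc(Cl)ccc1NC(=O)c1ccccn1)C2=O` has not been measured and arises from compound 2 by the same change, (chloro in place of bromo on an aromatic carbon). A step of similar size is expected, an at least 10-fold lower number from compound 2 to compound 4 (1.00 log units; beyond the scatter), resting on an at least 45-fold lower number from compound 1 to compound 3 (1.65 log units; beyond the scatter), though the limit for compound 2 leaves the starting point open. Compound 4 is estimated at 10000 nM, expected between 1500 nM and 100000 nM.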

Compound 4, half-maximal effective concentration: > 100000 nM
Compound 4: a limit, no number; the forecaster's own chance of this, stated with the estimate: 40%; middle value at least 10-fold (1.00 log units) away from the limit.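

Compound 2 and compound 4 both give only a limit in this assay, and the step between them cannot be read. The compounds shown leave open what chloro in place of bromo does on the core of compound 2.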